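This account rests on a few compounds, and the source may have more. Where it says the series, first, only, none or still open, it means among the compounds named here.

Of the compounds shown here, two have been measured in a functional assay on DU-145 cells (Homo sapiens) for inhibition, read by trypan blue exclusion, with a stated time of 96 h; on this read-out higher numbers stand for weaker inhibition of growth and lower numbers for stronger inhibition of growth. Compound 1 `Cc1cc(C)cc(/C=C(/SCc2ccc(F)cc2)C(=O)c2ccc(Br)cc2)c1` gives 10000 nM and compound 2 `O=C(O)c1ccc(C(=O)/C(=C\c2ccc(F)c([N+](=O)[O-])c2)SCc2ccc(C(F)(F)F)cc2)cc1` gives 1000 nM in the same test, a gap beyond the usual scatter. Compound 1 therefore holds the higher of the two numbers and shows the weaker inhibition of growth. Compound 3 `O=C(/C(=C\c1ccc(O)cc1)SCc1ccc(F)cc1)c1ccc(Br)cc1` has not yet been measured. It carries 4-hydroxyphenyl in place of 3,5-dimethylphenyl on a double-bonded chain carbon bound to a double-bonded chain carbon. For the measured compounds named here, no measured step shows what this change does, so the expectation in this assay is loose: a moderate move toward a lower number, with little change also possible. The expected size of the move is a 3.3-fold lower number from compound 1 to compound 3 (0.52 log units; beyond the scatter) on this estimate. For compound 3 the estimated value is 3000 nM with an expected range from 700 nM to 10000 nM in this read-out.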

Compound 3, concentration for 50% growth inhibition: 10000 nM
For compound 3 the middle estimate is 3.3-fold (0.52 log units) below the measured one, and the stated range covers the measured number.
By their numbers in this assay, from the lowest: compound 2; then compounds 1 and 3 (each within the scatter of the next).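

For the compounds shown here, with the swap of 4-hydroxyphenyl for 3,5-dimethylphenyl on a double-bonded chain carbon bound to a double-bonded chain carbon, this assay gives no change at the digits printed from compound 1 to compound 3 (within the scatter), the first reading of any change at this position. In this pair, a group that brings a hydrogen-bond donor and a hydrogen-bond acceptor can replace one that has neither, with no shift in the number beyond the scatter. Nothing available explains this result.

The compounds shown leave open whether an amine or a carboxylic acid on this phenyl ring would move the number in this assay. They also leave open whether the same swap would give a similar result with the other groups of the core of compound 1 changed.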